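The source may hold more compounds than are shown below. What is called first, only, known or untested is meant among the compounds shown, and "the series" means these compounds.

Compound 1 `CN(C(=O)NC(=O)c1ccccc1F)c1nc(C(F)(F)F)c(C(=O)N/N=C/c2ccccc2C(F)(F)F)s1` gives 5.39 ug/mL in a functional assay on HepG2 cells (Homo sapiens) for inhibition, read by MTT assay, with a stated time of 72 h; a higher number here means a weaker inhibitor, a lower number a stronger inhibitor. Compound 3 `CN(C(=O)NC(=O)c1ccccc1F)c1nc(C(F)(F)F)c(C(=O)N/N=C/c2ccc(C(F)(F)F)cc2)s1` gives 4.56 ug/mL in this assay; its core differs from that of compound 1 by 4-(trifluoromethyl)phenyl in place of 2-(trifluoromethyl)phenyl on a carbon with a double bond to nitrogen, and the step is a 1.2-fold lower number from compound 1 to compound 3 (0.07 log units; within the scatter). Compound 2 `CNc1nc(C(F)(F)F)c(C(=O)N/N=C/c2ccccc2C(F)(F)F)s1` reaches only a limit of this assay, > 100 ug/mL. The change from compound 1 to compound 2 is hydrogen in place of ((2-fluorophenyl)carbonyl)carbamoyl on a nitrogen on an aromatic ring, and the step is an at least 18-fold higher number from compound 1 to compound 2 (1.26 log units; beyond the scatter). Compound 4 `CNc1nc(C(F)(F)F)c(C(=O)N/N=C/c2ccc(C(F)(F)F)cc2)s1` has not yet been measured. It differs from compound 3 by hydrogen in place of ((2-fluorophenyl)carbonyl)carbamoyl on a nitrogen on an aromatic ring, the same change at a place described in the same words. The step is expected to be similarly large, an estimated 33-fold higher number from compound 3 to compound 4 (1.52 log units; beyond the scatter), because compound 2 already sits at the limit of > 100 ug/mL in this assay, at which 1 of the 3 values shown sits. Compound 4 is therefore estimated at 150 ug/mL, with a range of 40 ug/mL to 600 ug/mL.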

Compound 4, half-maximal inhibitory concentration: > 100 ug/mL
Compound 4: a limit, no number (the forecaster's own chance of this, stated with the estimate: 80%); the middle value lies beyond the limit too.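

In this assay putting hydrogen in place of ((2-fluorophenyl)carbonyl)carbamoyl on the nitrogen gives an at least 21-fold higher number from compound 3 to compound 4 (1.34 log units; beyond the scatter) on this second core. Compound 4 gives > 100 ug/mL in this assay as a limit and not a number. From the compounds shown here alone, the large weakening therefore carries over from the core of compound 1 to the core of compound 3, but its exact size on either core remains unknown: the same change on two cores in this assay, an at least 18-fold higher number (1.26 log units; beyond the scatter) from compound 1 to compound 2 and an at least 21-fold higher number (1.34 log units; beyond the scatter) from compound 3 to compound 4; the limit leaves it open whether they differ.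

The compounds shown leave open which part of the lost group is needed. A smaller acetyl group on that nitrogen, or a plain phenyl in place of 2-fluorophenyl, could show whether the lower numbers survive.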